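The source may report more compounds than this note shows. Statements on the series, on what has been measured and on what is new or still open speak of the compounds shown alone.

Measured so far in a functional assay on K562 cells (Homo sapiens) for antiproliferative activity, read by CCK-8 assay, with a stated time of 72 h; a lower number here means a stronger inhibitor of growth, a higher number a weaker inhibitor of growth:
Compound 1 `CCC1C(=O)N(C)c2cnc(-n3ccc4cc(C(N)=O)ccc43)nc2N1c1ccn(C)n1` gives 31300 nM.
Compound 2 `CCC1C(=O)N(C)c2cnc(-n3ccc4cc(C(=O)NC(C)C)ccc43)nc2N1c1ccn(C)n1` gives 8910 nM.
Compound 3 `CCCCNC(=O)c1ccc2c(ccn2-c2ncc3c(n2)N(C2CCCC2)[C@H](CC)C(=O)N3C)c1` gives 673 nM.

Compound 3 holds the lowest of the three numbers; compound 2 is nearest to it and compound 1 furthest, both gaps beyond the scatter. Compound 4 `CCNC(=O)c1ccc2c(ccn2-c2ncc3c(n2)N(C2CCCC2)[C@H](CC)C(=O)N3C)c1` differs from compound 3 in one place: hydrogen in place of ethyl on a saturated chain carbon, two bonds along the chain from an amide-type nitrogen. Among the measured compounds shown here, the only measured step that touches the amide substituent is a 3.5-fold lower number from compound 1 to compound 2 (0.55 log units; beyond the scatter), which went from hydrogen to a larger group and lowered the number. The change to compound 4 runs the other way, toward a smaller group, though it keeps a substituent rather than returning to hydrogen. Compounds 2 and 3 differ in more than one place, so their gap cannot be read as a step on this group alone. On this basis a modest rise in this assay is expected for compound 4, around a 1.8-fold higher number from compound 3 to compound 4 (0.25 log units; within the scatter). Compound 4 is estimated at 1200 nM, with a range of 500 nM to 3000 nM.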

Compound 4, concentration for 50% growth inhibition: 428 nM
Compound 4: the middle estimate sits 2.8-fold (0.45 log units) above what was measured; the whole stated range lies above it.
By their numbers in this assay, from the lowest: compounds 4 and 3 (each within the scatter of the next); then compound 2; then compound 1.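

In this assay, the change from butyl to ethyl, with hydrogen in place of ethyl on a saturated chain carbon, two bonds along the chain from an amide-type nitrogen, gives a 1.6-fold lower number from compound 3 to compound 4 (0.20 log units; within the scatter). The two chain lengths are therefore not separated in this assay, whereas the earlier step on the amide nitrogen, a 3.5-fold lower number from compound 1 to compound 2 (0.55 log units; beyond the scatter), lay beyond the scatter and involved a different change on a different compound pair. No supporting data bear on this result.

Still open, as far as these compounds go, is whether the amide on the core of compound 3 tolerates change beyond ethyl and butyl, for example a methyl group, a longer chain such as hexyl, or a chain ending in an amine or a carboxylic acid. The compounds shown also leave open whether the unsubstituted amide would give a number beyond the scatter of compound 4 on that same core.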